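Swapping a Chlorophenyl for a Dimethylphenyl: Cytotoxicity Outlook

The source may report more compounds than this note shows. Statements on the series, on what has been measured and on what is new or still open speak of the compounds shown alone.

Compound 2 `Cc1ccccc1-c1nn(-c2ccccc2Cl)cc1CNCCN1CCN(C)CC1` is one of three compounds examined so far in an ADME assay on Huh-7 cells (Homo sapiens) for cytotoxicity; on this read-out lower numbers stand for higher toxicity in this test and higher numbers for lower toxicity in this test. In this assay compound 2 gives > 20000 nM, which is a limit of the assay rather than a measured number. Compound 1 `Cc1ccccc1-c1nn(-c2ccc(F)cc2F)cc1CNCCN1CCCCC1` also gives > 20000 nM in this assay, again a limit. Compound 3 `CN1CCN(CCCNCc2cn(-c3ccc(C(F)(F)F)cc3)nc2-c2ccc(C(F)(F)F)cc2)CC1`, which carries two trifluoromethyl groups, gives 2000 nM in this assay. Compound 2 therefore stands together with compound 1 at the limit of > 20000 nM in this assay, at which 2 of the 3 values shown sit. Compound 4 `Cc1ccc(-n2cc(CNCCN3CCN(C)CC3)c(-c3ccccc3C)n2)c(C)c1` has not yet been measured; it differs from compound 2 in a single place: 2,4-dimethylphenyl in place of 2-chlorophenyl on an aromatic nitrogen. Among the measured compounds shown here, no measured pair isolates this change, so the outlook rests on compound 2 and compound 1 both sitting at the limit of > 20000 nM in this assay, at which 2 of the 3 values shown sit. The step from compound 2 to compound 4 is expected to be a number no higher from compound 2 to compound 4 (the limit leaves the size open), nothing beyond the usual scatter. Compound 4 is accordingly estimated at 20000 nM, with a range from 8000 nM to 50000 nM, and a fair chance that only a limit is reported again.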

Compound 4, half-maximal cytotoxic concentration: > 20000 nM
Compound 4 gave a limit, no number; the forecaster's own chance of this, stated with the estimate: 60%; the middle value lies on the limit itself.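

Compound 2 and compound 4 both end at a limit of this assay, not at a number, so the step between them cannot be read. The compounds shown leave open whether 2,4-dimethylphenyl in place of 2-chlorophenyl changes the cytotoxicity at all.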